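Trading a Carbamoyl for a Pentyl Chain

The compounds below may be only part of what the source reports. "The series", "measured", "known", "first", "only" and "open" are said of these compounds alone.

Compound 1 `NC(=O)Cn1c(=O)n(C2OC(CO)[C@@H](O)[C@H]2O)c2nc(N)nc(O)c21` has the lower of the two numbers seen so far in a functional assay with Mus musculus as the target (on this read-out lower numbers stand for an effect already at smaller amounts and higher numbers for an effect only at larger amounts of compound), where compound 1 gives 117 uM. Compound 2 `C=CCSc1nc2c(O)nc(N)nc2n1C1OC(CO)[C@@H](O)[C@H]1O` gives 485 uM in this assay, a gap beyond the usual scatter. Compound 3 `CCCCCCn1c(=O)n(C2OC(CO)[C@@H](O)[C@H]2O)c2nc(N)nc(O)c21` is reached from compound 1 by a single change: pentyl in place of carbamoyl on a saturated chain carbon bound to an aromatic nitrogen. For the measured compounds named here, no pair of measured compounds differing in just one place exists here, so the size of such a step is unknown. Compound 3 is expected to stay close to compound 1, with the expected step of a 1.3-fold higher number from compound 1 to compound 3 (0.11 log units; within the scatter) within the scatter, though the uncertainty is wide. The estimate for compound 3 is 150 uM, ranging from 40 uM to 600 uM.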

Compound 3, concentration for half-maximal effect: 600 uM
Compound 3: the middle estimate sits 4.0-fold (0.60 log units) below what was measured; low and high end bracket the measured number.
By their numbers in this assay, from the lowest: compound 1; then compounds 2 and 3 (each within the scatter of the next).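

For the compounds shown here, this is the first step that can be read at this position: in this assay, pentyl in place of carbamoyl on a saturated chain carbon bound to an aromatic nitrogen gives a 5.1-fold higher number from compound 1 to compound 3 (0.71 log units; beyond the scatter). Carbamoyl and pentyl are therefore not interchangeable here, even though the rest of the molecule stays the same. No measurement at hand says why the number rises.

Losing the carbamoyl and lengthening the chain happen together in this one step, so their shares remain open. A short ethyl chain, or an amine or carboxylic acid at the chain end, could help to tell them apart.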